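Carbamoyl in place of aminomethyl link on a pyrazole chain

The compounds below may be only part of what the source reports. "The series", "measured", "known", "first", "only" and "open" are said of these compounds alone.

compound 1 `CCCCCCCCCCCC[C@@H](O)[C@H]1CC[C@H]([C@H](O)CCCCCCCCCCNC(=O)c2ccnn2C)O1`: 8510 nM
compound 2 `CCCCCCCCCCCC[C@@H](O)[C@H]1CC[C@H]([C@H](O)CCCCCCCCCCNCc2ccnn2C)O1`: 2190 nM

In a functional assay on MDA-MB-231 cells (Homo sapiens) for inhibition, read by sulforhodamine B assay, with a stated time of 48 h (a lower number here means a stronger inhibitor of growth, a higher number a weaker inhibitor of growth), only these two compounds have been measured, and compound 2 stands lower of the pair at 2190 nM. For the measured compounds named here, the one measured step is modest but real: a 3.9-fold lower number from compound 1 to compound 2 (0.59 log units; beyond the scatter), with (1-methyl-1H-pyrazol-5-yl)methyl in place of (1-methyl-1H-pyrazol-5-yl)carbonyl on an amine nitrogen.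

The move to compound 3 `CCCCCCCCCCCC[C@@H](O)[C@H]1CC[C@H]([C@H](O)CCCCCCCCCCC(=O)Nc2ccnn2C)O1` is (1-methyl-1H-pyrazol-5-yl)carbamoyl in place of ((1-methyl-1H-pyrazol-5-yl)methyl)amino on a saturated chain carbon, ten or more bonds along the chain from an oxygen on a saturated carbon and a saturated ring carbon. It lies on a saturated chain carbon.

Like compound 1, compound 3 carries a carbonyl, though within a carbamoyl group that no measured compound holds. That step is therefore only a rough guide, and a change of similar size towards a higher number is expected. The estimated change is a 2.7-fold higher number from compound 2 to compound 3 (0.44 log units; beyond the scatter). For compound 3 the estimated value is 6000 nM, with an expected range of 2500 nM to 15000 nM.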

Compound 3, concentration for 50% growth inhibition: 100000 nM
For compound 3 the middle estimate is 17-fold (1.22 log units) below the measured one; the measured number lies above the stated range.
By their numbers in this assay, from the lowest: compound 2; then compound 1; then compound 3.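

In this assay, the end of this chain proved sensitive not only to whether the link holds a carbonyl but also to which way the link runs: with (1-methyl-1H-pyrazol-5-yl)carbamoyl in place of ((1-methyl-1H-pyrazol-5-yl)carbonyl)amino, the result was a 12-fold higher number from compound 1 to compound 3 (1.07 log units; beyond the scatter), even though both compounds carry a carbonyl. Against the amine link the loss was greater still, at a 46-fold higher number from compound 2 to compound 3 (1.66 log units; beyond the scatter), which leaves compound 3 the weakest inhibitor of growth of the three. Nothing given here accounts for these differences.

As far as these compounds go, it remains open whether a (1-methyl-1H-pyrazol-5-yl)methyl group on the amide nitrogen would recover growth inhibition, or whether the loss would persist. Also open, from the compounds shown here alone, is how this carbamoyl link would behave with a phenyl or imidazole ring in place of the pyrazole, or with a longer chain.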